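Swapping Bromine for Chlorine on a Fused Aromatic Ring

The source may hold more compounds than are shown below. What is called first, only, known or untested is meant among the compounds shown, and "the series" means these compounds.

Measured compounds:
Compound 1, `CCN(CC)CN1C(=O)/C(=N\c2nc3ccc(C)cc3s2)c2ccccc21`: 74800 nM in a functional assay on MCF7 cells (Homo sapiens) for cytotoxicity, read by sulforhodamine B assay, with a stated time of 48 h; a higher number here means a weaker inhibitor of growth, a lower number a stronger inhibitor of growth
Compound 2, `Cc1ccc2nc(/N=C3\C(=O)N(CN(c4ccccc4)c4ccccc4)c4cccc(Br)c43)sc2c1`: 30200 nM in this assay

Compound 2 holds the lower of the two numbers, and its gap to compound 1 lies beyond the usual scatter, so compound 2 is the stronger inhibitor of growth of the pair. Compound 3, `Cc1ccc2nc(/N=C3\C(=O)N(CN(c4ccccc4)c4ccccc4)c4cccc(Cl)c43)sc2c1`, has not yet been measured. It differs from compound 2 in one place: chloro in place of bromo on an aromatic carbon. For the measured compounds named here, no step between two measured compounds shows what this exchange does here, and the two halogens are counted the same in every respect apart from their identity. The step from compound 2 to compound 3 is therefore expected to be small, with no clear direction, and most likely inside the scatter: a 1.2-fold higher number from compound 2 to compound 3 (0.06 log units; within the scatter). Compound 3 is estimated at 35000 nM in this assay, with a likely range from 15000 nM to 80000 nM.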

Compound 3, concentration for 50% growth inhibition: 24300 nM
Beside the measured number, compound 3's estimate is 1.4-fold (0.16 log units) above it; the range from low to high includes it.
By their numbers in this assay, from the lowest: compounds 3 and 2 (each within the scatter of the next); then compound 1.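

In this assay, for the compounds shown here, the exchange of bromo for chloro on this aromatic carbon gives a 1.2-fold lower number from compound 2 to compound 3 (0.09 log units; within the scatter) and is the first measured step at this position. The two halogens therefore cannot be told apart here, since the step stays within the scatter. A chlorine can stand in place of the bromine on this six-membered aromatic ring without a change that can be read from this measurement. No supporting measurement is available to explain this result.

Still open, as far as these compounds go, is whether this carbon tolerates only halogens, or whether a very different group, such as an amine, a methoxy group or a carboxylic acid, would also leave the number in the same range. Also open, from the compounds shown here alone, is whether the same exchange would give a similarly small step on the core of compound 1, which differs from compound 2 in more than one place.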